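The source may hold more compounds than are shown below. What is called first, only, known or untested is meant among the compounds shown, and "the series" means these compounds.

Measured so far:
compound 1 `CCOc1ccc(NCN2C(=O)c3ccccc3C2=O)cc1`, 590 nM in an assay on isolated protein for inhibition of ribosomal protein S6 kinase alpha-2 (Homo sapiens), read by fluorescence, with a stated time of 20 min; a higher number here means a weaker inhibitor, a lower number a stronger inhibitor
compound 2 `CCOc1ccc(NCN2C(=O)c3ccc([N+](=O)[O-])cc3C2=O)cc1`, 2830 nM
compound 3 `COc1ccc(NCN2C(=O)c3ccc(NC(=O)c4ccccc4)cc3C2=O)cc1`, 2160 nM

Compound 3 stands second highest of the three numbers in this assay; its value and that of compound 2 lie within the scatter of each other, while compound 1 sits lower, beyond the scatter. Among the compounds with values here, the only measured step, a 4.8-fold higher number from compound 1 to compound 2 (0.68 log units; beyond the scatter), concerns a nitro group on the shared core and does not touch the change now in view.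

Compound 4 `CCOc1ccc(NCN2C(=O)c3ccc(NC(=O)c4ccccc4)cc3C2=O)cc1` differs from compound 3 by methyl in place of hydrogen on a saturated chain carbon bound to an oxygen on an aromatic ring. Within the data shown here, no measured pair in this set carries that change, so nothing here points to a shift in either direction. The expected step of a 1.1-fold lower number from compound 3 to compound 4 (0.03 log units; within the scatter) is therefore judged to stay within the scatter. Compound 4 is estimated at 2000 nM, with a range of 900 nM to 4500 nM.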

Compound 4, half-maximal inhibitory concentration: 4580 nM
Estimate against measurement, compound 4: 2.3-fold (0.36 log units) below, and the stated range ends below it.
By their numbers in this assay, from the lowest: compound 1; then compounds 3, 2 and 4 (each within the scatter of the next, the first and the last beyond it).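

In this assay, within the data shown here, the first measured step at this place shows that methoxy to ethoxy is not silent on the benzamido-bearing core (a 2.1-fold higher number from compound 3 to compound 4 (0.33 log units; beyond the scatter)). With ethoxy held, benzamido in place of hydrogen costs more (a 7.8-fold higher number from compound 1 to compound 4 (0.89 log units; beyond the scatter)), whereas benzamido in place of nitro stays within the scatter (a 1.6-fold higher number from compound 2 to compound 4 (0.21 log units; within the scatter)), leaving those two groups unseparated here. No measurement available speaks to the reason for these steps.

Open, going by these compounds, is whether a longer chain such as propoxy extends the methoxy to ethoxy trend. Also open, on these data alone, is whether a small amine on that aromatic carbon behaves like benzamido and nitro.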